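This account rests on a few compounds, and the source may have more. Where it says the series, first, only, none or still open, it means among the compounds named here.

Measured compounds:
- compound 1, `Nc1n[nH]c2cc(CC3CCNCC3)[nH]c(=O)c12`, 6%
- compound 2, `Cc1cc2c(c(N)nn2C)c(=O)[nH]1`, 4%
- compound 3, `CC(C)(C)c1cc2nn(-c3ccccc3)c(N)c2c(=O)[nH]1`, 3%

All three compounds were examined in an assay on isolated protein for inhibition of RAC-beta serine/threonine-protein kinase (Homo sapiens), read by mobility shift assay, tested at 30 uM (on this read-out higher numbers stand for more inhibition at the one concentration tested (going by the name of the read-out) and lower numbers for less inhibition), and none of them gave more than a slight signal. Compound 3 has the smallest of the three numbers, but its gap to compound 2 and its gap to compound 1 both lie within the scatter of the measurement, so nothing separates compound 3 from the other two on these numbers. Among the compounds with values here, no pair among the measured compounds differs in a single place, so no measured step can be drawn on to gauge the effect of a substituent change.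

Compound 4, `COc1ccc(-c2cc3nn(-c4ccccc4)c(N)c3c(=O)[nH]2)cc1`, is the untested member of this set. It differs from compound 3 in one place:

4-methoxyphenyl in place of tert-butyl on an aromatic carbon

Within the data shown here, with no comparable step among the measured compounds, the expected step in this assay rests only on the flat picture they give. A small step is expected from compound 3 to compound 4, most likely in the direction of a somewhat larger number, and not clearly beyond the scatter: a number 5 percentage points higher from compound 3 to compound 4 (within the scatter). On that basis compound 4 is estimated to give 8% in this assay, within a range from 0% to 25%.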

Compound 4, a percentage reported as inhibition, at one concentration (the size of the read-out at that concentration, not a potency): 0%
For compound 4 the middle estimate is 8 percentage points above the measured one; low and high end bracket the measured number.
By their numbers in this assay, from the lowest: compounds 4, 3, 2 and 1 (each within the scatter of the next).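

In this assay, within the data shown here, putting 4-methoxyphenyl in place of tert-butyl on the aromatic carbon next to the ring nitrogen gives a number 3 percentage points lower from compound 3 to compound 4 (within the scatter) as the first step in the set that can be read at a single place. A group of 4 heavy atoms with no ring thus gives way to one of 8 heavy atoms with a six-membered aromatic ring and a hydrogen-bond acceptor, and the read-out stays as slight as before, so neither addition brings out inhibition at the one concentration tested. No measured property of these compounds bears on this result, and the numbers give no explanation for it.

As far as these compounds go, whether an amine, a carboxylic acid or a longer chain on this aromatic carbon would lift the number clear of the scatter remains open, as does the result for a plain phenyl without its methoxy group. The compounds shown also leave open whether replacing the phenyl shared by compound 3 and compound 4 with a smaller group such as methyl would change the picture in this assay at all.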